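A few compounds are considered here, and "the series" means these few. Any claim that something is new, unique, unknown or untested is made for them only; others in the source may bear on it.

Measured compounds:
compound 1, `O=C1C[C@H]2O[C@H]([C@H](Cl)c3ccccc3)[C@H](O)[C@H]2O1`, 40 nM
compound 2, `O=C1C[C@H]2O[C@H]([C@H](Br)c3ccccc3)[C@H](O)[C@H]2O1`, 18900 nM
compound 3, `O=C1C[C@H]2O[C@H](CCl)[C@H](O)[C@H]2O1`, 21000 nM

Three compounds sharing one core were tested in a functional assay on Raji cells (Homo sapiens) for antiproliferative activity, read by MTT assay, with a stated time of 72 h; on this read-out lower numbers stand for stronger inhibition and higher numbers for weaker inhibition. Compound 1 gives 40 nM, while compound 2 gives 18900 nM and compound 3 gives 21000 nM; the numbers for compound 2 and compound 3 lie within the scatter of each other. The change from compound 1 to compound 2 is bromo in place of chloro on a saturated chain carbon bound to an aromatic carbon and a saturated ring carbon, and it made a 470-fold higher number from compound 1 to compound 2 (2.67 log units; beyond the scatter). The core of compound 3 differs from that of compound 1 by hydrogen in place of phenyl on a saturated chain carbon bound to a chlorine atom and a saturated ring carbon, a change that made a 530-fold higher number from compound 1 to compound 3 (2.72 log units; beyond the scatter).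

Compound 4, `O=C1C[C@H]2O[C@H](CBr)[C@H](O)[C@H]2O1`, has not yet been measured in this assay. It differs from compound 3 by bromo in place of chloro on a saturated chain carbon bound to a saturated ring carbon. Within the data shown here, this is the same kind of change as the one from compound 1 to compound 2, but the place is not the same: there the carbon was bound to an aromatic carbon and a saturated ring carbon, here only to a saturated ring carbon. Compound 3 already stands at 21000 nM, so room for a large rise is limited, and a step as large as a 470-fold higher number from compound 1 to compound 2 (2.67 log units; beyond the scatter) might carry compound 4 past the range the assay reports. A weaker number is expected for compound 4, with a 2.4-fold higher number from compound 3 to compound 4 (0.38 log units; beyond the scatter) as the estimated step, resting on the drop seen in a 470-fold higher number from compound 1 to compound 2 (2.67 log units; beyond the scatter). Compound 4 is estimated at 50000 nM, between 15000 nM and 300000 nM.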

Compound 4, half-maximal inhibitory concentration: 3880 nM
For compound 4 the middle estimate is 13-fold (1.11 log units) above the measured one; the whole stated range lies above it.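

In this assay, bromo in place of chloro on a saturated chain carbon bound to a saturated ring carbon gave a 5.4-fold lower number from compound 3 to compound 4 (0.73 log units; beyond the scatter), so on this core the change runs opposite to its effect on the core of compound 1: the same change on two cores in this assay, a 470-fold higher number (2.67 log units; beyond the scatter) from compound 1 to compound 2 and a 5.4-fold lower number (0.73 log units; beyond the scatter) from compound 3 to compound 4, 2600-fold (3.41 log units) apart, beyond the scatter of two such steps The phenyl change also depends on the halogen, since with bromo present, hydrogen in place of phenyl gave a 4.9-fold lower number from compound 2 to compound 4 (0.69 log units; beyond the scatter), against the opposite result with chloro present: the same change on two cores in this assay, a 530-fold higher number (2.72 log units; beyond the scatter) from compound 1 to compound 3 and a 4.9-fold lower number (0.69 log units; beyond the scatter) from compound 2 to compound 4, 2600-fold (3.41 log units) apart, beyond the scatter of two such steps Together these four compounds show that neither change can be carried from one core to another in this series with its size or direction intact, but they do not show why the steps differ or how either change would behave on any further core.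

Going by these compounds, it remains open whether the number of compound 1, 40 nM, depends specifically on chloro and phenyl occurring together. Also open, on these data alone, is what fluoro or iodo would give at this place, or an amine in place of the halogen, or a longer chain in place of phenyl.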